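The source may hold more compounds than are shown below. What is called first, only, known or untested is meant among the compounds shown, and "the series" means these compounds.

Measured compounds in the series:

compound 1 `COc1ccc(-c2cc(=O)c3c(OC)cc(OC)cc3n2C)cc1`: 68000 nM
compound 2 `COc1ccc(-c2c(Br)c(=O)c3c(OC)cc(OC)cc3n2S(=O)(=O)c2ccc(OC)cc2)cc1`: 49700 nM
compound 3 `COc1ccc(-c2cc(=O)c3c(OC)cc(OC)cc3n2S(=O)(=O)c2ccc([N+](=O)[O-])cc2)cc1`: > 29300 nM

All three were run in an ADME assay on BJ cells (Homo sapiens) for antiproliferative activity, with a stated time of 72 h; on this read-out higher numbers stand for an effect only at larger amounts of compound and lower numbers for an effect already at smaller amounts. Compound 1 gives 68000 nM and compound 2 gives 49700 nM; the two numbers lie within the scatter of each other, so no order between them is claimed. Compound 3 stands apart in that its value is a limit of the assay, not a number: compound 3 is recorded as > 29300 nM. This is the limit of > 29300 nM in this assay, at which 1 of the 3 values shown sits, so compound 3 shows no effect up to the highest amount tested, and nothing finer can be said about where it sits.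

The next compound, compound 4 `COc1ccc(-c2cc(=O)c3c(OC)cc(OC)cc3n2S(=O)(=O)c2cc(F)c(F)c(F)c2)cc1`, differs from compound 3 in one place: 3,4,5-trifluorophenyl in place of 4-nitrophenyl on a sulfonyl sulfur, on a sulfonyl sulfur whose other neighbour is the aromatic nitrogen of the shared core. For the measured compounds named here, no step between measured compounds covers a change of this kind, so there is no measured step to lean on. Given that compound 1 and compound 2 give weak numbers and compound 3 gives only a limit, the expectation is that compound 4 stays in the same weak region, with no step beyond the scatter and a fair chance that the assay again reports a limit. The step from compound 3 to compound 4 is thus expected to be about a step that the limit leaves unreadable from compound 3 to compound 4, within the scatter. For compound 4 the estimate in this assay is 40000 nM, with a range from 15000 nM to 100000 nM.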

Compound 4, half-maximal effective concentration: > 65500 nM
Compound 4 gave a limit, no number (the forecaster's own chance of this, stated with the estimate: 60%); at least 1.6-fold (0.21 log units) between middle value and limit.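

In this assay compound 3 is recorded as > 29300 nM, a limit of the assay. For the compounds shown here, compound 4 is recorded as > 65500 nM, also a limit, so no step between compound 3 and compound 4 can be read. The compounds shown leave open whether 4-nitrophenyl or 3,4,5-trifluorophenyl on the sulfonyl sulfur gives the stronger effect, or any effect at all.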